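Amide nitrogen substituent change in a nitroisoxazole series

A few compounds are considered here, and "the series" means these few. Any claim that something is new, unique, unknown or untested is made for them only; others in the source may bear on it.

The study covers four compounds that share one core. Compound 1 `COC(=O)c1c([N+](=O)[O-])noc1-c1ccc(Cl)cc1` gives "not determined" (no result reported) in an ADME assay on J774.A1 cells (Mus musculus) for cytotoxicity, read by MTT assay, with a stated time of 48 h (a lower number here means that less compound is tolerated, a higher number that more compound is tolerated), and compound 2 `O=C(Nc1ccccc1)c1c([N+](=O)[O-])noc1-c1ccc([N+](=O)[O-])cc1` likewise gives "not determined" (no result reported), so neither gives a point of comparison. Compound 3 `O=C(Nc1ccccc1)c1c([N+](=O)[O-])noc1-c1ccc(Cl)cc1` is the only compound with a result: in this assay compound 3 gives 89300 nM, and it therefore stands alone on the numbers shown. Compound 4 `COc1ccc(CNC(=O)c2c([N+](=O)[O-])noc2-c2ccc(Cl)cc2)cc1` is still to be measured in this assay. It differs from compound 3 in one place, (4-methoxybenzyl in place of phenyl on an amide-type nitrogen). Among the compounds with values here, with no step between measured compounds to draw on, the step of a 1.1-fold lower number from compound 3 to compound 4 (0.05 log units; within the scatter) is expected to stay within the usual scatter, in no clear direction. Compound 4 is therefore estimated at 80000 nM in this assay, within a range from 30000 nM to 200000 nM.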

Compound 4, half-maximal cytotoxic concentration: 89500 nM
Compound 4: the middle estimate sits 1.1-fold (0.05 log units) below what was measured; the measured number falls inside the stated range.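

In this assay, within the data shown here, 4-methoxybenzyl in place of phenyl on the amide-type nitrogen gives a 1.0-fold higher number from compound 3 to compound 4 (0.00 log units; within the scatter), the only step here that can be read; those involving compound 1 or compound 2 cannot. On this nitrogen, then, cells tolerate compound 3 and compound 4 alike, although the entering group adds heavy atoms and a hydrogen-bond acceptor. Nothing available explains why the two groups read alike.

The compounds shown leave open whether a carboxylic acid, an amine or a longer chain on this nitrogen would read the same.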